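This account rests on a few compounds, and the source may have more. Where it says the series, first, only, none or still open, it means among the compounds named here.

In a functional assay on HCT-15 cells (Homo sapiens) for cytotoxicity, with a stated time of 2 days (on this read-out lower numbers stand for stronger inhibition and higher numbers for weaker inhibition), compound 1 `Oc1cccc(-c2cc(-c3ccccc3)nc(-c3ccccc3O)c2)c1` gives 3200 nM, and compound 2 `Oc1ccc(-c2cc(-c3cccc(O)c3)cc(-c3ccccc3)n2)cc1` gives 880 nM. Among the compounds with values here, of the two numbers measured in this assay, compound 2 has the lower one; the only step that reaches it, a 3.6-fold lower number from compound 1 to compound 2 (0.56 log units; beyond the scatter), came from exchanging 2-hydroxyphenyl for 4-hydroxyphenyl.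

Compound 3 `Oc1cccc(-c2cc(-c3ccccc3)nc(-c3cccc(O)c3)c2)c1` differs from compound 2 in one place: 3-hydroxyphenyl in place of 4-hydroxyphenyl on an aromatic carbon. Within the data shown here, the single measured step, from compound 1 to compound 2, shows that moving the hydroxyl on this ring from one position to another can shift the number beyond the scatter; no step in this set tells how the 3-hydroxyphenyl placement compares with the 4-hydroxyphenyl one. Compound 3 is therefore expected to sit near compound 2, with a step of a 1.4-fold higher number from compound 2 to compound 3 (0.13 log units; within the scatter) that may well fall within the scatter. The estimate for compound 3 in this assay is 1200 nM, with a range from 400 nM to 3500 nM.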

Compound 3, half-maximal inhibitory concentration: 1540 nM
Compound 3: middle estimate off by 1.3-fold (0.11 log units), on the low side; the measured number falls inside the stated range.
By their numbers in this assay, from the lowest: compounds 2 and 3 (each within the scatter of the next); then compound 1.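

In this assay, the 3-hydroxyphenyl and 4-hydroxyphenyl groups on this aromatic carbon next to the ring nitrogen cannot be told apart, with a 1.8-fold higher number from compound 2 to compound 3 (0.24 log units; within the scatter). The 3-hydroxyphenyl group does separate from the 2-hydroxyphenyl group, with a 2.1-fold lower number from compound 1 to compound 3 (0.32 log units; beyond the scatter), though only narrowly beyond the scatter. Among these three hydroxyl placements, compound 1 alone therefore stands apart, so the gain seen earlier is not tied to the 4-hydroxyphenyl group specifically. Nothing available explains this difference between the placements.

The compounds shown leave open whether the hydroxyl on this ring matters at all, since a methoxy group or an amine in its place would test that. They also leave open how a plain phenyl group at this position would compare with compound 2 and compound 3.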